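The source may hold more compounds than are shown below. What is called first, only, known or untested is meant among the compounds shown, and "the series" means these compounds.

Three compounds sharing one core have been run in a functional assay on MCF7 cells (Homo sapiens) for cytotoxicity, read by MTT assay, with a stated time of 48 h; a lower number here means a stronger inhibitor, a higher number a weaker inhibitor. Compound 1 `CCCCCCCCNC(=O)[C@@H](NC(=O)c1cccs1)[C@@H](C)O` gives 72500 nM. Compound 2 `CCCCCCCCNC(=O)[C@@H](NC(=O)c1nccc2ccccc12)[C@@H](C)O` gives 63200 nM. Compound 3 `CCCCCCCCCCCCNC(=O)[C@@H](NS(=O)(=O)c1ccc(C)cc1)[C@@H](C)O` gives 31100 nM. Compound 2 stands second highest of the three numbers; its gap to compound 1 is within the scatter, while its gap to compound 3 lies beyond it, compound 3 showing the lower number. Within the data shown here, no pair among the three differs in one place only, so no single step is counted; compound 3 differs from compound 2 both in the chain and elsewhere.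

The next compound, compound 4 `CCCCCCCCCCCCCCNC(=O)[C@@H](NC(=O)c1nccc2ccccc12)[C@@H](C)O`, keeps the core of compound 2 and changes it by hexyl in place of hydrogen on a saturated chain carbon, eight bonds along the chain from an amide-type nitrogen. In this assay a lowering step of modest size is expected, resting on compound 3 with its longer chain and 31100 nM, though that comparison carries a second change as well. The estimate for compound 4 in this assay is 35000 nM, with a range from 15000 nM to 80000 nM. The expected step of a 1.8-fold lower number from compound 2 to compound 4 (0.26 log units; within the scatter) is estimated to sit at the edge of the scatter.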

Compound 4, half-maximal inhibitory concentration: 22800 nM
For compound 4 the middle estimate is 1.5-fold (0.19 log units) above the measured one, within the range that was stated.
By their numbers in this assay, from the lowest: compounds 4 and 3 (each within the scatter of the next); then compounds 2 and 1 (each within the scatter of the next).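

In this assay, among these compounds, hexyl in place of hydrogen on a saturated chain carbon, eight bonds along the chain from an amide-type nitrogen, gives a 2.8-fold lower number from compound 2 to compound 4 (0.44 log units; beyond the scatter) and this is the first step with a single change. The step lies beyond the scatter, so a change at this position alone, with the rest of compound 2 held fixed, is enough to move the number. No measured evidence bears on this step, and its cause stays unassigned.

A single step shows one chain length against one other and gives no trend with length. Going by these compounds, whether a longer chain lowers the number further, or an amine or a carboxylic acid in place of hexyl at this position moves it, remains open.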